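The source may hold more compounds than are shown below. What is called first, only, known or untested is meant among the compounds shown, and "the series" means these compounds.

Measured compounds in an assay on isolated protein for binding affinity to leukotriene B4 receptor 1 (Homo sapiens), tested at 1 uM; a higher number here means more inhibition at the concentration tested (going by the name of the read-out), a lower number less inhibition:
Compound 1, `CCCCc1cc(C(C)=O)c(O)cc1OCCCCC#N`, gives 13%.
Compound 2, `C=CCc1cc(C(C)=O)c(O)cc1OCCCCC#N`, gives 57%.
Compound 3, `C=CCc1cc(C(C)=O)c(O)cc1OCCCCCCC`, gives 8%.

Compound 3 shows the lowest of the three numbers; its gap to compound 1 lies within the scatter, and the step of a number 49 percentage points lower from compound 2 to compound 3 (beyond the scatter) is the only one that separates it clearly. Within the measured set, the step of a number 44 percentage points higher from compound 1 to compound 2 (beyond the scatter) corresponds to the change (vinyl in place of propyl on a saturated chain carbon bound to an aromatic carbon).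

Compound 4, `C=CCCCCOc1cc(O)c(C(C)=O)cc1CC=C`, is not yet measured. It differs from compound 3 by vinyl in place of propyl on a saturated chain carbon, four bonds along the chain from an oxygen on an aromatic ring. This is the same kind of change as that from compound 1 to compound 2, but not the same: in compound 1 the place is on a saturated chain carbon bound to an aromatic carbon, whereas in compound 3 it is on a saturated chain carbon, four bonds along the chain from an oxygen on an aromatic ring. The difference between the core of compound 1 and the core of compound 3 is not broken down here.

Because a number 44 percentage points higher from compound 1 to compound 2 (beyond the scatter) was large, some rise is expected for compound 4, yet the different place and the low starting number of compound 3 8% argue for a smaller step, estimated at a number 12 percentage points higher from compound 3 to compound 4 (beyond the scatter). The value expected for compound 4 is 20%, between 5% and 45%.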

Compound 4, a percentage reported as inhibition, at one concentration (the size of the read-out at that concentration, not a potency): 27%
Compound 4: the middle estimate sits 7 percentage points below what was measured; low and high end bracket the measured number.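

In this assay, vinyl in place of propyl goes with a higher number on both cores, but the size of the step does not carry over from one to the other: the same change on two cores in this assay, a number 44 percentage points higher (beyond the scatter) from compound 1 to compound 2 and a number 19 percentage points higher (beyond the scatter) from compound 3 to compound 4, 25 percentage points apart, beyond the scatter of two such steps On the chain bound through the aromatic oxygen, the change gives a number 19 percentage points higher from compound 3 to compound 4 (beyond the scatter), while vinyl in place of cyano at that same place gives a number 30 percentage points lower from compound 2 to compound 4 (beyond the scatter), so the cyano-bearing compound 2 keeps a clear lead over the vinyl-bearing compound 4. The two vinyl-for-propyl steps differ in both place and core, so these compounds show the direction recurring in two pairs but cannot separate the effect of place from that of core, and they give no rule for other cores.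

Open, from the compounds shown here alone, is how an amine, a carboxylic acid or an amide would compare with cyano and vinyl at that place on the chain. Going by these compounds, a longer chain carrying the cyano group, and a saturated ring-bound chain paired with the vinyl-ended chain, also remain open.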